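The source may report more compounds than this note shows. Statements on the series, on what has been measured and on what is new or still open speak of the compounds shown alone.

Measured compounds:
Compound 1 `CO[C@@H]1[C@@H](O)[C@@H](O)[C@H](Oc2ccc3cc(NC(=O)C4CCCC4)c(=O)oc3c2C)OC1(C)C` — 67000 nM
Compound 2 `CCCCCCC(=O)Nc1cc2ccc(O[C@@H]3OC(C)(C)[C@H](OC)[C@@H](O)[C@H]3O)c(C)c2oc1=O` — 58300 nM
Compound 3 `CO[C@@H]1[C@@H](O)[C@@H](O)[C@H](Oc2ccc3cc(NC(=O)C4CCCCC4)c(=O)oc3c2C)OC1(C)C` — 46800 nM

These three compounds were tested in a functional assay on SK-BR-3 cells (Homo sapiens) for antiproliferative activity; a higher number here means a weaker inhibitor, a lower number a stronger inhibitor. Compound 1 gives the highest number of the three, but its nearest neighbour is compound 2, with a 1.1-fold lower number from compound 1 to compound 2 (0.06 log units; within the scatter), and the furthest is compound 3, with a 1.4-fold lower number from compound 1 to compound 3 (0.16 log units; within the scatter); both steps are within the scatter, so the three numbers cannot be told apart.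

Compound 4 `CCCC(=O)Nc1cc2ccc(O[C@@H]3OC(C)(C)[C@H](OC)[C@@H](O)[C@H]3O)c(C)c2oc1=O` has not yet been measured. It differs from compound 1 in one place: propyl in place of cyclopentyl on a carbonyl carbon. The measured steps that bear on this change are those that also alter the group on the carbonyl carbon, namely a 1.1-fold lower number from compound 1 to compound 2 (0.06 log units; within the scatter) and a 1.4-fold lower number from compound 1 to compound 3 (0.16 log units; within the scatter), and also a 1.2-fold lower number from compound 2 to compound 3 (0.10 log units; within the scatter). Each of these changes that group without moving the number beyond the scatter. Among the measured compounds shown here, no measured step shortens the group to propyl, so the direction is uncertain, and the expectation is a step of about a 1.1-fold higher number from compound 1 to compound 4 (0.05 log units; within the scatter), not beyond the scatter. Compound 4 is therefore estimated at 75000 nM, with a likely range from 35000 nM to 160000 nM.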

Compound 4, half-maximal inhibitory concentration: 313000 nM
Compound 4: middle estimate off by 4.2-fold (0.62 log units), on the low side; the whole stated range lies below it.
By their numbers in this assay, from the lowest: compounds 3, 2 and 1 (each within the scatter of the next); then compound 4.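

In this assay, the group on the carbonyl carbon turns out to matter: swaps among cyclopentyl, hexyl and cyclohexyl stayed within the scatter, yet propyl in place of cyclopentyl gives a clear move to a weaker inhibitor (a 4.7-fold higher number from compound 1 to compound 4 (0.67 log units; beyond the scatter)). The same holds against the cyclohexyl compound (a 6.7-fold higher number from compound 3 to compound 4 (0.83 log units; beyond the scatter)) and against the hexyl compound (a 5.4-fold higher number from compound 2 to compound 4 (0.73 log units; beyond the scatter)), so among these four compounds, a ring is not required, since open-chain hexyl stays with the two ring groups and only the shorter propyl chain stands apart. Nothing measured here explains this loss.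

Where between propyl and hexyl the change sets in remains open, and a butyl or pentyl chain would help locate it. Also open, going by these compounds, is how a phenyl ring or an amine at this position would compare.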